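Nitro Substitution on a Shared Core and Paw Edema Inhibition

The source may hold more compounds than are shown below. What is called first, only, known or untested is meant among the compounds shown, and "the series" means these compounds.

Compound 1 `Cc1ccc(Nc2nn(-c3ccccc3)c3nc(Nc4ccccc4)n(-c4ccccc4)c(=O)c23)cc1` was tested in a functional assay on the whole organism (strain Wistar albino) for inhibition, with Rattus norvegicus as the target, read by paw edema, with a stated time of 1 h, at a dose of 25 mg/kg by the oral route (on this read-out lower numbers stand for less inhibition and higher numbers for more inhibition at the one dose given (going by the name of the read-out)), and compound 1 gives 55.7%. Compound 2 `Cc1ccc(Nc2nn(-c3ccc([N+](=O)[O-])cc3)c3nc(Nc4ccccc4)n(-c4ccccc4)c(=O)c23)cc1` differs from it by nitro in place of hydrogen on an aromatic carbon; in this assay compound 2 gives 46.6%, and the step is a number 9.1 percentage points lower from compound 1 to compound 2 (within the scatter). Compound 3 `O=c1c2c(Nc3ccc(Cl)cc3)nn(-c3ccccc3)c2nc(Nc2ccccc2)n1-c1ccccc1` carries a different core, the difference from compound 1 being (chloro in place of methyl on an aromatic carbon); in this assay compound 3 gives 47.6%. Compound 4 `O=c1c2c(Nc3ccc(Cl)cc3)nn(-c3ccc([N+](=O)[O-])cc3)c2nc(Nc2ccccc2)n1-c1ccccc1` has not yet been measured. It differs from compound 3 by nitro in place of hydrogen on an aromatic carbon, the same change seen between the two measured compounds, at the same place. Because that earlier change gave a number 9.1 percentage points lower from compound 1 to compound 2 (within the scatter), a step of similar size is expected here, namely a number 7.6 percentage points lower from compound 3 to compound 4 (within the scatter). Compound 4 is therefore estimated at 40%, with an expected range from 28% to 52%.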

Compound 4, a percentage reported as inhibition, in the whole organism at one dose (the size of the read-out at that dose, not a potency): 39.6%
Compound 4: middle estimate off by 0.4 percentage points, on the high side; low and high end bracket the measured number.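

In this assay, nitro in place of hydrogen gives a number 8 percentage points lower from compound 3 to compound 4 (within the scatter), which matches the same change made earlier with the methyl group in place: the same change on two cores in this assay, a number 9.1 percentage points lower (within the scatter) from compound 1 to compound 2 and a number 8 percentage points lower (within the scatter) from compound 3 to compound 4, 1.1 percentage points apart, within the scatter of two such steps

Chloro in place of methyl, read on the nitro-bearing pair as a number 7 percentage points lower from compound 2 to compound 4 (within the scatter), also repeats its earlier step: the same change on two cores in this assay, a number 8.1 percentage points lower (within the scatter) from compound 1 to compound 3 and a number 7 percentage points lower (within the scatter) from compound 2 to compound 4, 1.1 percentage points apart, within the scatter of two such steps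

For the compounds shown here, each of these steps lies within the scatter, however; the agreement shows only that the two changes repeat in size across these compounds, not that either one really alters inhibition or would carry over to a further core.

The compounds shown leave open what an amine or a carboxylic acid would do in place of the nitro group. They also leave open how inhibition would respond at other doses.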